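Thiophen-2-yl on the Fused Core: Expected Cell Inhibition

The source may report more compounds than this note shows. Statements on the series, on what has been measured and on what is new or still open speak of the compounds shown alone.

Measured compounds:
Compound 1, `C=C(Br)C(=O)Nc1cccc(-c2cn3nc(-c4ccc(C)cc4)sc3n2)c1`, 920 nM
Compound 2, `C=C(Br)C(=O)Nc1cccc(-c2cn3nc(CCc4ccccc4)sc3n2)c1`, 2200 nM
Compound 3, `C=C(Br)C(=O)Nc1cccc(-c2cn3nc(Cc4ccc(OC)cc4)sc3n2)c1`, 1400 nM

In a functional assay on L1210 cells (Mus musculus) for inhibition, read by cell counting, with a stated time of 2 days (on this read-out higher numbers stand for weaker inhibition and lower numbers for stronger inhibition), compound 3 gives the second highest of the three numbers; its steps to compound 1 and to compound 2 both stay within the scatter. Compound 4, `C=C(Br)C(=O)Nc1cccc(-c2cn3nc(-c4cccs4)sc3n2)c1`, differs from compound 3 by thiophen-2-yl in place of 4-methoxybenzyl on an aromatic carbon. For the measured compounds named here, no measured step is the same change, but two bear on it: a 1.5-fold higher number from compound 1 to compound 3 (0.18 log units; within the scatter) and a 2.4-fold higher number from compound 1 to compound 2 (0.38 log units; beyond the scatter), which together hint that a group attached directly as an aromatic ring sits at or below a benzyl or phenethyl group. For compound 4 a small lower number is therefore expected, likely within the scatter, giving an estimated 1.4-fold lower number from compound 3 to compound 4 (0.15 log units; within the scatter). Compound 4 is estimated at 1000 nM, between 450 nM and 2200 nM.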

Compound 4, half-maximal inhibitory concentration: 170 nM
Estimate against measurement, compound 4: 5.9-fold (0.77 log units) above; the whole stated range lies above it.
By their numbers in this assay, from the lowest: compound 4; then compounds 1, 3 and 2 (each within the scatter of the next, the first and the last beyond it).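

In this assay, thiophen-2-yl on this aromatic carbon of the shared core sets compound 4 apart from all three earlier compounds (an 8.2-fold lower number from compound 3 to compound 4 (0.92 log units; beyond the scatter); a 13-fold lower number from compound 2 to compound 4 (1.11 log units; beyond the scatter); a 5.4-fold lower number from compound 1 to compound 4 (0.73 log units; beyond the scatter)). A directly attached aromatic ring alone is not enough for this lower number: compound 1 carries one as well. No measurement at hand accounts for the gain.

Going by these compounds, whether the sulfur, the five-membered ring or both matter remains open, and furan-2-yl, thiophen-3-yl or unsubstituted phenyl here would separate these. So does whether an amine or a carboxylic acid on the thiophene keeps the gain.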